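The compounds below may be only part of what the source reports. "The series", "measured", "known", "first", "only" and "open" are said of these compounds alone.

Measured compounds:
Compound 1 `CC(C)(C)c1cc(NC(=O)c2c(Cl)cc(N)cc2Cl)ccc1O` gives 5200 nM in an assay on isolated protein for antagonist activity at Bile acid receptor (Homo sapiens), read by HTRF, with a stated time of 30 min; a higher number here means a weaker inhibitor, a lower number a stronger inhibitor.
Compound 2 `CC(C)(C)c1cc(NC(=O)c2c(Cl)cc(NCc3cccs3)cc2Cl)ccc1O` gives 8600 nM in this assay.
Compound 3 `CNc1cc(Cl)c(C(=O)Nc2ccc(O)c(C(C)(C)C)c2)c(Cl)c1` gives 13900 nM in this assay.

Compound 3 has the highest number of the three. Its nearest neighbour is compound 2, and the step of a 1.6-fold higher number from compound 2 to compound 3 (0.21 log units; within the scatter) is within the scatter, so the two cannot be ordered. Against compound 1 the step of a 2.7-fold higher number from compound 1 to compound 3 (0.43 log units; beyond the scatter) is beyond the scatter, so compound 3 is the weaker inhibitor of that pair.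

Compound 4 `CC(C)(C)c1cc(NC(=O)c2c(Cl)cc(NC3CCCC3)cc2Cl)ccc1O` differs from compound 3 by cyclopentyl in place of methyl on a nitrogen on an aromatic ring. Going by the values given here, two measured steps bear on this change. Adding a small group to this nitrogen, a 2.7-fold higher number from compound 1 to compound 3 (0.43 log units; beyond the scatter), raised the number modestly; adding a larger group instead, a 1.7-fold higher number from compound 1 to compound 2 (0.22 log units; within the scatter), stayed within the scatter, and the bulky compound 2 sits no worse than compound 3. A larger group on this nitrogen thus has not pushed the number further up, so compound 4 is expected to show no step beyond the scatter, a 1.4-fold lower number from compound 3 to compound 4 (0.14 log units; within the scatter), and its value is estimated at 10000 nM, between 4500 nM and 24000 nM.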

Compound 4, half-maximal inhibitory concentration: 5000 nM
For compound 4 the middle estimate is 2.0-fold (0.30 log units) above the measured one, and the stated range covers the measured number.
By their numbers in this assay, from the lowest: compounds 4, 1, 2 and 3 (each within the scatter of the next, the first and the last beyond it).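

Putting cyclopentyl in place of methyl on this nitrogen lowers the number (a 2.8-fold lower number from compound 3 to compound 4 (0.44 log units; beyond the scatter)), so the rise seen with methyl does not carry over to every group placed there. Even so, the cyclopentyl compound cannot be ordered against the compound with only hydrogen on the nitrogen (a 1.0-fold lower number from compound 1 to compound 4 (0.02 log units; within the scatter)) or against the one carrying (thiophen-2-yl)methyl (a 1.7-fold lower number from compound 2 to compound 4 (0.24 log units; within the scatter)), so among these four compounds only the methyl compound, compound 3, stands apart from any other, and no group yet beats plain hydrogen. No measurement shown here explains the difference between methyl and cyclopentyl.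

The compounds shown leave open how other groups on this nitrogen would behave, such as an open chain like isopropyl or a larger ring like cyclohexyl. A group carrying an amine or a carboxylic acid also remains an open case.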